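A few compounds are considered here, and "the series" means these few. Any claim that something is new, unique, unknown or untested is made for them only; others in the source may bear on it.

Going by the values given here, compound 1, `CCCCCCCCc1ccc(OCC(=O)Cn2nnc(-c3ccccc3Cl)n2)cc1`, and compound 2, `CCCCCCCCc1ccc(OCC(=O)Cn2nnnc2-c2ccc(S(=O)(=O)N(C)C)cc2)cc1`, are the two measured members. In an assay on microsomes from brain for inhibition of Fatty-acid amide hydrolase 1 (Rattus norvegicus), read by fluorescence and HPLC, with a stated time of 60 min (on this read-out higher numbers stand for weaker inhibition and lower numbers for stronger inhibition), compound 1 gives 32 nM. In this assay compound 2 gives 1400 nM, the highest of the two numbers, and the distance to compound 1 is well beyond the scatter of repeated measurements, so compound 2 is the weaker inhibitor of the pair. Among the compounds with values here, no single-point step connects these two compounds: they differ in more than one place, so nothing can be read from them about any one change.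

The unmeasured compound 3, `CCCCCCCCc1ccc(OCC(=O)Cn2nnnc2Cc2ccccc2)cc1`, differs from compound 2 in one place: benzyl in place of 4-(dimethylsulfamoyl)phenyl on an aromatic carbon. Within the data shown here, the two measured compounds alone give no direct precedent for this exchange.

With that limited basis, compound 3 is expected to show a step of a 4.7-fold lower number from compound 2 to compound 3 (0.67 log units; beyond the scatter) in this assay, toward stronger inhibition, though a result within the scatter cannot be excluded. For compound 3 the estimated value in this assay is 300 nM, expected to fall between 60 nM and 1500 nM.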

Compound 3, half-maximal inhibitory concentration: 320 nM
Estimate against measurement, compound 3: 1.1-fold (0.03 log units) below; low and high end bracket the measured number.
By their numbers in this assay, from the lowest: compound 1; then compound 3; then compound 2.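

In this assay, going by these compounds alone, placing benzyl instead of 4-(dimethylsulfamoyl)phenyl on the aromatic carbon of the five-membered aromatic ring with 4 nitrogen gives a 4.4-fold lower number from compound 2 to compound 3 (0.64 log units; beyond the scatter), the first single-place step and a modest move toward stronger inhibition. It shows that the read-out responds to the group at this position and that a group made of carbon only, with no hydrogen-bond acceptors, is accepted there without loss of inhibition. The exchange alters several things at once, removing the dimethylsulfamoyl group and also placing a methylene link before the six-membered aromatic ring, and no measurement at hand accounts for the step.

The compounds shown do not separate those two parts of the exchange, which a plain phenyl at this position would begin to do. They also leave open how far the number would move with a longer chain such as phenethyl, or with an amine or a carboxylic acid on the benzyl ring.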